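A few compounds are considered here, and "the series" means these few. Any claim that something is new, unique, unknown or untested is made for them only; others in the source may bear on it.

In an in vivo ADME assay on the whole organism for pharmacokinetics, with Canis familiaris (Canis lupus familiaris) as the target (a lower number here means that more of the compound stays in the plasma, a higher number that more of the compound sits outside the plasma), compound 3 `Cc1nn(-c2ccc3onc(N)c3c2)c2c1CCN(c1ccc(-c3ccccc3CN3CCCC3)cc1)C2=O` gives 3.3 L/kg. Compound 1 `Nc1noc2ccc(-n3nc(C(F)(F)F)c4c3C(=O)N(c3ccc(-c5ccccc5CN5CCCC5)cc3F)CC4)cc12`, at 4.8 L/kg, lies within the scatter of that number, while compound 2 `CN(C)Cc1ccccc1-c1ccc(N2CCc3c(C(F)(F)F)nn(-c4ccc5onc(N)c5c4)c3C2=O)c(F)c1`, at 8.8 L/kg, lies beyond the scatter above it. Compound 4 `Nc1noc2ccc(-n3nc(C(F)(F)F)c4c3C(=O)N(c3ccc(-c5ccccc5CN5CCCC5)cc3)CC4)cc12` differs from compound 3 by trifluoromethyl in place of methyl on an aromatic carbon. For the measured compounds named here, no measured step isolates this change. The only one available, a 1.8-fold higher number from compound 1 to compound 2 (0.26 log units; within the scatter), concerns the amine instead and stays within the scatter. Compound 1, which also carries trifluoromethyl, gives 4.8 L/kg, so no shift beyond the scatter is expected. The expected change is a 1.2-fold higher number from compound 3 to compound 4 (0.08 log units; within the scatter). The estimate for compound 4 is 4 L/kg, with an expected range of 2.3 L/kg to 7 L/kg.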

Compound 4, volume of distribution at steady state: 5 L/kg
Estimate against measurement, compound 4: 1.3-fold (0.10 log units) below, within the range that was stated.
By their numbers in this assay, from the lowest: compounds 3, 1, 4 and 2 (each within the scatter of the next, the first and the last beyond it).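

In this assay trifluoromethyl in place of methyl on this aromatic carbon of the five-membered ring gives a 1.5-fold higher number from compound 3 to compound 4 (0.18 log units; within the scatter) and so is now measured directly rather than inferred. Hydrogen in place of fluoro on an aromatic carbon gives a 1.0-fold higher number from compound 1 to compound 4 (0.02 log units; within the scatter) and so isolates that fluoro for the first time. No measured property bears on either step.

Open, as far as these compounds go, is whether nitrile or a longer chain on this aromatic carbon also stays within the scatter. Also open, from the compounds shown here alone, is whether a carboxylic acid in place of the pyrrolidin-1-yl amine moves the number beyond it.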